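Acetylphenylamino series: trifluoromethyl for phenyl on compound 1

The compounds below may be only part of what the source reports. "The series", "measured", "known", "first", "only" and "open" are said of these compounds alone.

In a functional assay on HOP-62 cells (Homo sapiens) for inhibition, read by sulforhodamine B assay, with a stated time of 48 h, tested at 10 uM (a lower number here means less inhibition of growth, a higher number more inhibition of growth at the concentration tested), compound 1 `CC(=O)c1cccc(Nc2ccnc(SCC(=O)c3ccc(-c4ccccc4)cc3)n2)c1` gives 19%, the highest of the three numbers, though compound 2 `CC(=O)c1ccc(Nc2ccnc(SCC(=O)c3ccc(Cl)cc3)n2)cc1` with 14% and compound 3 `CC(=O)c1ccc(Nc2ccnc(SCC(=O)c3ccc(-c4ccccc4)cc3)n2)cc1` with 13% both lie within the scatter of it. The steps of a number 6 percentage points lower from compound 1 to compound 3 (within the scatter) and a number 1 percentage points lower from compound 2 to compound 3 (within the scatter) are likewise within the scatter. Compound 4 `CC(=O)c1cccc(Nc2ccnc(SCC(=O)c3ccc(C(F)(F)F)cc3)n2)c1` differs from compound 1 by trifluoromethyl in place of phenyl on an aromatic carbon. Within the data shown here, the step from compound 2 to compound 3 is the only measured exchange on an aromatic carbon at that place, and it changed nothing beyond the scatter; no step involving trifluoromethyl has been measured. For compound 4 in this assay a step of a number 2 percentage points lower from compound 1 to compound 4 (within the scatter) is therefore expected, not beyond the scatter. Compound 4 is estimated at 17%, with a range from 5% to 30%.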

Compound 4, percent growth inhibition at one concentration: 17%
Compound 4: the middle estimate sits on the measured number at the digits printed; low and high end bracket the measured number.
By their numbers in this assay, from the lowest: compounds 3, 2, 4 and 1 (each within the scatter of the next).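

Trifluoromethyl in place of phenyl on an aromatic carbon, para to a large group, gives a number 2 percentage points lower from compound 1 to compound 4 (within the scatter) in this assay, so a group with no ring stands at this position with no change beyond the scatter. This is a second exchange at this place that stays within the scatter, now with the 3-acetylphenyl group present rather than the 4-acetylphenyl group. No measurement bears on why the number holds here.

On these data alone, whether an amine, a carboxylic acid or a longer chain at this position would move the number beyond the scatter remains open. Also open, as far as these compounds go, is whether trifluoromethyl gives the same result alongside the 4-acetylphenyl group.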